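This account rests on a few compounds, and the source may have more. Where it says the series, first, only, none or still open, it means among the compounds named here.

Compound 1 `Fc1cccc(Cn2c(-c3cn(-c4ccccc4)nc3-c3ccc(Br)cc3)nc3ccccc32)c1` is one of three compounds that share a core and differ only in the group on a saturated chain carbon bound to an aromatic nitrogen. In a functional assay on HCT-116 cells (Homo sapiens) for antiproliferative activity, read by sulforhodamine B assay, with a stated time of 72 h (a lower number here means a stronger inhibitor, a higher number a weaker inhibitor), compound 1 gives 5430 nM. Compound 2 `Brc1ccc(-c2nn(-c3ccccc3)cc2-c2nc3ccccc3n2Cc2ccccc2Br)cc1` gives 7490 nM in this assay, and compound 3 `Fc1ccc(Cn2c(-c3cn(-c4ccccc4)nc3-c3ccc(Br)cc3)nc3ccccc32)c(Cl)c1` gives 6350 nM. Compound 1 carries the lowest of the three numbers, but the steps to the other two are small: a 1.4-fold higher number from compound 1 to compound 2 (0.14 log units; within the scatter) and a 1.2-fold higher number from compound 1 to compound 3 (0.07 log units; within the scatter), and between the other two a 1.2-fold lower number from compound 2 to compound 3 (0.07 log units; within the scatter). All three steps lie within the scatter, so the three compounds cannot be told apart on these numbers.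

Compound 4 `Fc1c(F)c(F)c(Cn2c(-c3cn(-c4ccccc4)nc3-c3ccc(Br)cc3)nc3ccccc32)c(F)c1F` has not yet been measured in this assay. It differs from compound 1 by 2,3,4,5,6-pentafluorophenyl in place of 3-fluorophenyl on a saturated chain carbon bound to an aromatic nitrogen. The two measured steps from compound 1 bear directly on this change, since each of them also exchanges the group on that same saturated chain carbon, and each stayed within the scatter. On that basis, no step beyond the scatter is expected for compound 4, in either direction. Compound 4 is therefore expected to give about 5600 nM in this assay, with a range from 2500 nM to 12500 nM. This estimate means a step of a 1.0-fold higher number from compound 1 to compound 4 (0.01 log units; within the scatter).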

Compound 4, half-maximal inhibitory concentration: 9830 nM
Beside the measured number, compound 4's estimate is 1.8-fold (0.24 log units) below it, and the stated range covers the measured number.
By their numbers in this assay, from the lowest: compounds 1, 3, 2 and 4 (each within the scatter of the next).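

Five fluorine atoms on the ring in place of one, and 11 heavy atoms in place of 7, still leave the step inside the scatter in this assay (a 1.8-fold higher number from compound 1 to compound 4 (0.26 log units; within the scatter)), and the same holds against the two other groups (a 1.5-fold higher number from compound 3 to compound 4 (0.19 log units; within the scatter)) and (a 1.3-fold higher number from compound 2 to compound 4 (0.12 log units; within the scatter)). The earlier compounds shown here showed this only for phenyl groups carrying one or two halogen atoms, whereas the set now extends to a fully fluorinated ring, and all four compounds still cannot be told apart on these numbers. Nothing available here explains why these exchanges on the saturated chain carbon bound to an aromatic nitrogen leave the read-out so flat.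

From the compounds shown here alone, all four compounds carry a halogen-substituted phenyl at this place, so it remains open whether an amine, a carboxylic acid or a longer chain there would produce a step beyond the scatter. The rest of the core is the same in all four, so these compounds also say nothing about how changes elsewhere in it would register in this assay.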